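Mirror image of a thiourea iminosugar against beta-galactosidase

The source may report more compounds than this note shows. Statements on the series, on what has been measured and on what is new or still open speak of the compounds shown alone.

Compounds measured so far:
compound 1, `CCCCCCCCCC/N=C1/SC[C@@H]2[C@@H](O)[C@H](O)[C@@H](CO)N12`, 93000 nM
compound 2, `CCCCCCCCCCCCNC(=S)N1[C@H](CO)[C@@H](O)[C@H](O)[C@H]1CO`, 24000 nM
compound 3, `CCCCCC/N=C1/SC[C@H]2[C@H](O)[C@@H](O)[C@H](CO)N12`, 599000 nM

In an assay for inhibition of beta-galactosidase (Bos taurus), read by spectrophotometry (on this read-out lower numbers stand for stronger inhibition and higher numbers for weaker inhibition), compound 2 gives the lowest of the three numbers; compound 1 sits nearest with a higher number beyond the scatter, and compound 3 is furthest away. Going by the values given here, no single-point steps connect these three compounds, so only their values can be compared. Compound 4, `CCCCCCCCCCCCNC(=S)N1[C@@H](CO)[C@H](O)[C@@H](O)[C@@H]1CO`, is the mirror image of compound 2: the two compounds have the same atoms and bonds and differ only in configuration as drawn: 4 of 4 stereo elements differ (all stereocentres are inverted: mirror images); a stereocentre at a saturated ring carbon is drawn R in compound 2 and S in compound 4; a stereocentre at a saturated ring carbon is drawn R in compound 2 and S in compound 4; a stereocentre at a saturated ring carbon is drawn R in compound 2 and S in compound 4; a stereocentre at a saturated ring carbon is drawn R in compound 2 and S in compound 4. Because compound 2 already gives 24000 nM, a weaker result is expected for compound 4, by a step well beyond the scatter. The expected step of a 6.3-fold higher number from compound 2 to compound 4 (0.80 log units; beyond the scatter) places compound 4 at an estimated 150000 nM, with a range from 40000 nM to 600000 nM.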

Compound 4, half-maximal inhibitory concentration: 30000 nM
For compound 4 the middle estimate is 5.0-fold (0.70 log units) above the measured one; the measured number lies below the stated range.
By their numbers in this assay, from the lowest: compounds 2 and 4 (each within the scatter of the next); then compound 1; then compound 3.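

In this assay the mirror-image pair gives a 1.3-fold higher number from compound 2 to compound 4 (0.10 log units; within the scatter), so this read-out does not separate the two configurations of the dodecyl thiourea. Going by these compounds alone, this is the first step that can be read as a single change, and it can be read as configuration alone because of this: the fact that compounds 2 and 4 differ only in the configuration as drawn. What stays open is whether the two mirror images would remain this close with an octyl chain or a carboxylic acid at the end of the chain, since the shown pair carries only the dodecyl chain.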